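Ring-nitrogen substituent swap on a dithiocarbamate benzamide

The source may hold more compounds than are shown below. What is called first, only, known or untested is meant among the compounds shown, and "the series" means these compounds.

Measured so far in a functional assay on HeLa cells (Homo sapiens) for antiproliferative activity, read by CCK-8 assay, with a stated time of 72 h, tested at 8 uM; a lower number here means a weaker effect, a higher number a stronger effect of the compound at the concentration tested:
compound 1 `Nc1ccccc1NC(=O)c1ccc(CSC(=S)N2CCN(Cc3ccncc3)CC2)cc1` gives 72.9%
compound 2 `Nc1ccccc1NC(=O)c1ccc(CSC(=S)N2CCN(c3ccccc3F)CC2)cc1` gives 59.2%

Compound 2 stands lowest of the two numbers; its nearest neighbour is compound 1, and the step of a number 13.7 percentage points lower from compound 1 to compound 2 (beyond the scatter) places compound 1 above it beyond the scatter. Compound 3 `Nc1ccccc1NC(=O)c1ccc(CSC(=S)N2CCN(c3cnccn3)CC2)cc1` is not yet measured. It differs from compound 2 in one place: pyrazin-2-yl in place of 2-fluorophenyl on an amine nitrogen in a ring. For the measured compounds named here, the only measured step, a number 13.7 percentage points lower from compound 1 to compound 2 (beyond the scatter), concerns a different exchange at the same ring nitrogen, so it does not speak directly to the change from 2-fluorophenyl to pyrazin-2-yl. Going by the values given here, no measured pair bears on it, and the expected step of a number 3.8 percentage points higher from compound 2 to compound 3 (within the scatter) is therefore set as small, without a clear direction beyond the scatter. On that basis compound 3 is estimated to give 63% in this assay, within a range from 45% to 80%.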

Compound 3, a percentage reported as inhibition, at one concentration (the size of the read-out at that concentration, not a potency): 76.9%
Estimate against measurement, compound 3: 13.9 percentage points below, and the stated range covers the measured number.
By their numbers in this assay, from the lowest: compound 2; then compounds 1 and 3 (each within the scatter of the next).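

In this assay, for the compounds shown here, replacing 2-fluorophenyl with pyrazin-2-yl on the amine nitrogen in the ring gives a number 17.7 percentage points higher from compound 2 to compound 3 (beyond the scatter), the first sign that a change of the ring held directly on this nitrogen can move the read-out beyond the scatter. The other comparison, with (pyridin-4-yl)methyl in compound 1, gives a number 4 percentage points higher from compound 1 to compound 3 (within the scatter), so the lower number of compound 2 is not shared by every six-membered aromatic ring at this position. Nothing available explains the difference between these groups.

The compounds shown leave open whether a plain phenyl, a pyridin-2-yl or a pyrimidin-2-yl group here would stand with compound 2 or with compound 3. They also leave open whether the fluorine or the ring nitrogens of the two groups account for the gap.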